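Taking One Acetyl off a Trisaccharide Ester

The compounds below may be only part of what the source reports. "The series", "measured", "known", "first", "only" and "open" are said of these compounds alone.

Three glycosides built on a shared core have been tested in a functional assay on Lu1 cells (Homo sapiens) for cytotoxicity; a lower number here means that less compound is needed, a higher number that more compound is needed for the effect. Compound 2 `CCCCCCCCO[C@@H]1O[C@@H](C)[C@H](OC(=O)CCCCC)[C@@H](O[C@@H]2O[C@@H](C)[C@H](OC(C)=O)[C@@H](O[C@@H]3O[C@@H](C)[C@H](OC(C)=O)[C@@H](OC(C)=O)[C@H]3O)[C@H]2OC(C)=O)[C@H]1O` gives 11.8 ug/mL in this assay, the lower of the two numbers obtained. Compound 1 `CCCCCCCCO[C@@H]1O[C@@H](C)[C@H](OC(=O)CCCCC)[C@@H](O[C@@H]2O[C@@H](C)[C@H](OC(C)=O)[C@@H](O[C@@H]3O[C@@H](C)[C@H](O)[C@@H](O)[C@H]3OC(C)=O)[C@H]2OC(C)=O)[C@H]1O`, which carries the acetyl and hydroxy groups of its outermost sugar in a different arrangement, gives 19.7 ug/mL, and the gap between compound 1 and compound 2 lies within the scatter of repeated measurements, so the two cannot be told apart on these numbers. For compound 3 `CCCCCCCCO[C@@H]1O[C@@H](C)[C@H](OC(=O)CCCCC)[C@@H](O[C@@H]2O[C@@H](C)[C@H](OC(C)=O)[C@@H](O)[C@H]2OC(C)=O)[C@H]1O`, a shorter analogue, this assay reports > 20 ug/mL, which is a limit and not a number: it sits at the limit of > 20 ug/mL in this assay, at which 1 of the 3 values shown sits.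

Compound 4 `CCCCCCCCO[C@@H]1O[C@@H](C)[C@H](OC(=O)CCCCC)[C@@H](O[C@@H]2O[C@@H](C)[C@H](OC(C)=O)[C@@H](O[C@@H]3O[C@@H](C)[C@H](OC(C)=O)[C@@H](O)[C@H]3O)[C@H]2OC(C)=O)[C@H]1O` has not yet been measured. It differs from compound 2 in one place: hydrogen in place of acetyl on an oxygen on a saturated carbon. For the measured compounds named here, no measured pair differs by this change alone, so the size of the step is open. The step from compound 2 to compound 4 is expected to be modest, a 1.4-fold higher number from compound 2 to compound 4 (0.13 log units; within the scatter), pointing towards a higher number or to nothing beyond the scatter. Compound 4 is therefore estimated at 16 ug/mL in this assay, within a range from 8 ug/mL to 32 ug/mL, with a real chance that only a limit is reported.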

Compound 4, concentration for half-maximal effect: 19.4 ug/mL
Beside the measured number, compound 4's estimate is 1.2-fold (0.08 log units) below it; the measured number falls inside the stated range.
By their numbers in this assay, from the lowest: compounds 2, 4 and 1 (each within the scatter of the next). At a limit, above all of these: compound 3.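

Hydrogen in place of acetyl on an oxygen on a saturated carbon now has a size of its own in this assay, and this single change amounts to a 1.6-fold higher number from compound 2 to compound 4 (0.22 log units; within the scatter). Removing this acetyl, which turns acetoxy into hydroxy, therefore leaves a result that cannot be told apart from the original, so this acetyl is not needed to keep the cytotoxicity read-out at the level seen here. Nothing among the results shown explains why the step is this small.

From the compounds shown here alone, it remains open whether this oxygen would tolerate more substantial replacements, such as a longer ester chain, or whether swapping the hydroxy for an amine would give a step beyond the scatter of repeated measurements. Going by these compounds, this one step also rests on a single cell line and a single pair of compounds, so it remains unknown whether the same change would be as small at other positions on the shared core or in other cells.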